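Moving one chlorine: from 4-chlorophenyl to 3-chlorophenyl

This account rests on a few compounds, and the source may have more. Where it says the series, first, only, none or still open, it means among the compounds named here.

- compound 1 `CN(C)C(=O)c1cc2cnc(Nc3ccc(NC(=O)C4(C(=O)Nc5ccc(F)cc5)CC4)cc3)nc2n1C1CCCC1`: 102%
- compound 2 `CN(C)C(=O)c1cc2cnc(Nc3ccc(NC(=O)C4(C(=O)Nc5ccc(Cl)cc5)CC4)cc3)nc2n1C1CCCC1`: 101%
- compound 3 `COc1ccc(NC(=O)C2(C(=O)Nc3ccc(Nc4ncc5cc(C(=O)N(C)C)n(C6CCCC6)c5n4)cc3)CC2)cc1`: 78.5%

These three compounds were tested in a functional assay on A549 cells (Homo sapiens) for inhibition, read by CCK-8 assay, with a stated time of 72 h, tested at 10 uM (on this read-out lower numbers stand for less inhibition of growth and higher numbers for more inhibition of growth at the one concentration tested), and they differ only in one group on an aromatic ring. The number for compound 2, 101%, cannot be told apart from that of compound 1. Only compound 3 lies clearly lower, with a gap of a number 22.5 percentage points lower from compound 2 to compound 3 (beyond the scatter).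

The untested compound 4 `CN(C)C(=O)c1cc2cnc(Nc3ccc(NC(=O)C4(C(=O)Nc5cccc(Cl)c5)CC4)cc3)nc2n1C1CCCC1` has the same atoms as compound 2, joined differently: 3-chlorophenyl in place of 4-chlorophenyl on an amide-type nitrogen. In words, it carries 3-chlorophenyl in place of 4-chlorophenyl on an amide-type nitrogen.

For the measured compounds named here, no measured step moves a group to another place on its ring, so the evidence is only indirect. Exchanging one halogen for the other changed little, a number 1 percentage points lower from compound 1 to compound 2 (within the scatter). Exchanging the halogen for methoxy gave the largest step seen, a number 23.5 percentage points lower from compound 1 to compound 3 (beyond the scatter). Compound 4 keeps its chlorine, so in this assay a step no larger than modest is expected, lower if anything, and quite possibly none beyond the scatter. The expected change is a number 9 percentage points lower from compound 2 to compound 4 (within the scatter). For compound 4 the estimated value is 92%, with an expected range from 72% to 106%.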

Compound 4, percent growth inhibition at one concentration: 90.7%
Compound 4: middle estimate off by 1.3 percentage points, on the high side; the range from low to high includes it.
By their numbers in this assay, from the lowest: compound 3; then compound 4; then compounds 2 and 1 (each within the scatter of the next).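

Moving the chlorine keeps every atom and changes only how they are joined, and in this assay this change at the amide-type nitrogen does register (a number 10.3 percentage points lower from compound 2 to compound 4 (beyond the scatter)). Among the compounds shown, then, the place of the chlorine on this ring counts as well as the choice of group, whereas exchanging one halogen for the other in compounds 1 and 2 gave no step beyond the scatter. Compound 4 also falls short of the fluoro compound (a number 11.3 percentage points lower from compound 1 to compound 4 (beyond the scatter)) yet stays clear of the methoxy compound (a number 12.2 percentage points higher from compound 3 to compound 4 (beyond the scatter)), so it sits in the middle of the set, with a step of modest size to each neighbour. Nothing available explains why the number moves with the chlorine's place.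

A single pair cannot tell whether 3-fluorophenyl or 3-methoxyphenyl would follow compound 4 or stay with their 4-substituted partners. It also remains open how an amine or a carboxylic acid on this ring would fare in place of the chlorine, and a reading at one concentration gives no full dose-response picture for any of these compounds.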